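Shortening a propyl chain on an inactive core

The source may hold more compounds than are shown below. What is called first, only, known or untested is meant among the compounds shown, and "the series" means these compounds.

Measured so far in a functional assay for inhibition, with Homo sapiens as the target; on this read-out lower numbers stand for stronger inhibition and higher numbers for weaker inhibition:
Compound 1, `CCCc1nc(C)c2c(C)nn(CCC)c(=O)n12`, gives > 48000 nM, which is a limit of the measurement rather than a number.
Compound 2, `CSc1nncc2c(C(C)C)ncn12`, gives > 48000 nM, again a limit rather than a number.

Compound 1 thus stands at the limit of > 48000 nM in this assay, at which 2 of the 2 values shown sit. For the measured compounds named here, both values shown sit at that limit, so no number places one compound above the other, and no step between measured compounds can be read. Compound 3, `CCCc1nc(C)c2c(C)nn(C)c(=O)n12`, differs from compound 1 by hydrogen in place of ethyl on a saturated chain carbon bound to an aromatic nitrogen. Going by the values given here, with both measured compounds returning only a limit, there is no measured step to lean on; the change from compound 1 to compound 3 is a modest trimming of a chain, and in this assay no movement beyond the usual scatter is expected in either direction. Compound 3 is therefore expected to give about 100000 nM, with a plausible range from 30000 nM to 400000 nM, most likely reported again only as a limit. The implied step that the limit leaves unreadable from compound 1 to compound 3 is expected to amount to no real change.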

Compound 3, half-maximal inhibitory concentration: > 48000 nM
Compound 3 gave a limit, no number; the forecaster's own chance of this, stated with the estimate: 85%; the middle value lies beyond the limit too.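

In this assay compound 3 gives > 48000 nM, which is a limit and not a number. For the compounds shown here, compound 1 also gives only a limit, so no step from compound 1 to compound 3 can be read. The compounds shown leave open whether going from propyl to methyl changes inhibition at all, because all their values share one mark: the limit of > 48000 nM in this assay, at which 3 of the 3 values shown sit.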